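From acetoxy to ethoxy on compound 2

The source may hold more compounds than are shown below. What is called first, only, known or untested is meant among the compounds shown, and "the series" means these compounds.

- Compound 1 `CCO[C@@H]1OC(=O)[C@](C)(C(C)=O)[C@@H]1C` gives > 50000 nM (a limit)
- Compound 2 `CC(=O)O[C@@H]1OC(=O)[C@@](C)(C(C)=O)[C@@H]1C` gives 14000 nM
- Compound 3 `CC(=O)O[C@@H]1OC(=O)[C@@](Cc2ccccc2)(C(C)=O)[C@@H]1C` gives 45000 nM

In a functional assay on B16 cells (Mus musculus) for cytotoxicity, read by MTT assay (a higher number here means a weaker inhibitor, a lower number a stronger inhibitor), compound 2 holds the lower of the two exact numbers. Going by the values given here, the only measured step, a 3.2-fold higher number from compound 2 to compound 3 (0.51 log units; beyond the scatter) (modest), lies at another place, on a saturated chain carbon, so it offers only a rough guide to size. Compound 4 `CCO[C@@H]1OC(=O)[C@@](C)(C(C)=O)[C@@H]1C` brings one change ethyl in place of acetyl on an oxygen on a saturated carbon. For compound 1, which also carries ethyl on that oxygen, the result is the limit of > 50000 nM in this assay, at which 1 of the 3 values shown sits (a limit). A modest step towards a higher number is therefore expected in this assay here. The expected change is a 3.0-fold higher number from compound 2 to compound 4 (0.48 log units; beyond the scatter) (an estimate). For compound 4 the estimated value is 42000 nM with an expected range from 16000 nM to 100000 nM (estimated).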

Compound 4, half-maximal inhibitory concentration: > 50000 nM
Compound 4 gave a limit, no number; the forecaster's own chance of this, stated with the estimate: 50%; at least 1.1-fold (0.07 log units) between middle value and limit.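

Changing only acetoxy to ethoxy gives an at least 3.5-fold higher number from compound 2 to compound 4 (0.55 log units; beyond the scatter) in this assay. Going by these compounds alone, this is the first reading of a single change on this oxygen, and it shows that acetyl there gives a measurable number while ethyl does not. Compound 4 gives a limit, not a number: the limit of > 50000 nM in this assay, at which 2 of the 4 values shown sit.

On these data alone, the step from compound 1 to compound 4 cannot be read, so the effect of configuration stays open: the fact that compounds 1 and 4 differ only in the configuration as drawn. Also open, as far as these compounds go, is whether propionyl or benzoyl in place of acetyl on that oxygen would stay close to compound 2.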